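A few compounds are considered here, and "the series" means these few. Any claim that something is new, unique, unknown or untested is made for them only; others in the source may bear on it.

The series comprises compound 1 (`CCCS(=O)(=O)c1cccc(C#Cc2cc(Cl)ccc2OCC(=O)O)c1`), compound 2 (`CN(C)S(=O)(=O)c1ccc(F)c(C#Cc2cc(Cl)ccc2OCC(=O)O)c1`) and compound 3 (`CCCS(=O)(=O)c1ccc(F)c(C#Cc2cc(Cl)ccc2OCC(=O)O)c1`). In an in vivo ADME assay on the whole organism (strain BALB/c) for pharmacokinetics, with Mus musculus as the target, read by LC-MS, at a dose of 5 mg/kg by the oral route (a lower number here means slower removal, a higher number faster removal of the compound), compound 1 gives 5 mL/min/kg and compound 2 gives 10 mL/min/kg. Among the compounds with values here, these two numbers lie within the usual scatter of each other, so compound 2 cannot be separated from the only other measured compound.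

The next structure, compound 3, comes from compound 2 by a single exchange: propyl in place of dimethylamino on a sulfonyl sulfur. In words, propyl takes the place of dimethylamino on a sulfonyl sulfur. Within the data shown here, no measured pair shows this change on its own, so the size of the step in this assay has no direct precedent. Among the measured compounds shown here, the only guide is that the entering propyl group, as part of a propylsulfonyl group, is also carried by compound 1, which gives 5 mL/min/kg. A modest move toward slower removal is therefore expected, but nothing beyond the scatter. The estimated change is a 1.4-fold lower number from compound 2 to compound 3 (0.15 log units; within the scatter). In this assay, compound 3 is expected at about 7 mL/min/kg, with an estimated range of 3.5 mL/min/kg to 14 mL/min/kg.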

Compound 3, clearance: 6.67 mL/min/kg
The estimate for compound 3 lay 1.0-fold (0.02 log units) above the measured number, within the range that was stated.
By their numbers in this assay, from the lowest: compounds 1, 3 and 2 (each within the scatter of the next).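

Within the data shown here, compound 3 gives the first direct reading of propyl in place of dimethylamino on a sulfonyl sulfur: in this assay the exchange amounts to a 1.5-fold lower number from compound 2 to compound 3 (0.18 log units; within the scatter), so this change leaves the two compounds inseparable at this position. It also gives a reading of fluoro in place of hydrogen on an aromatic carbon with the propylsulfonyl group kept, and in this assay this exchange amounts to a 1.3-fold higher number from compound 1 to compound 3 (0.13 log units; within the scatter), which again does not separate the pair. No supporting measurement is available that could explain either step.

On these data alone, since both single exchanges stay within the scatter, the three compounds do not show which groups on the sulfonyl sulfur or on that aromatic carbon could produce a clear difference in clearance, and it remains open whether a longer chain such as hexyl, or a cyclic amine such as morpholine, on the sulfur would do so. Also open, as far as these compounds go, is whether chloro or methoxy in place of the fluoro, or an amide in place of the carboxylic acid, would give a step beyond the scatter.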